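The compounds below may be only part of what the source reports. "The series", "measured", "known", "first", "only" and "open" are said of these compounds alone.

Series notes. Compound 1 `CCOC(=O)/C=C(C)/C=C/CC(C)CCC=C(C)C` gives 6.19 in a physicochemical assay for lipophilicity; on this read-out lower numbers stand for lower lipophilicity and higher numbers for higher lipophilicity. Compound 2 `CC(C)=CCCC(C)C/C=C/C(C)=C/C(=O)OC(C)C` gives 6.6 in this assay; the step is a number 0.41 log units higher from compound 1 to compound 2 (beyond the scatter), the change being (methyl in place of hydrogen on a saturated chain carbon bound to an oxygen next to a carbonyl group and a saturated chain carbon). Compound 3 `CCCC(=O)/C=C(C)/C=C/CC(C)CCCC(C)(C)OC` gives 5.61 in this assay, the lowest of the three measured numbers; how its core differs from that of compound 1 is not broken down here. Compound 4 `COC(C)(C)CCCC(C)C/C=C/C(C)=C/C(=O)CC(C)C` is not yet measured and differs from compound 3 by methyl in place of hydrogen on a saturated chain carbon bound to two saturated chain carbons. This is the same kind of change as that between compound 1 and compound 2, not the same one: there the carbon is bound to an oxygen next to a carbonyl group and a saturated chain carbon, here to two saturated chain carbons. A step of similar size is expected from compound 3 to compound 4, a number 0.44 log units higher from compound 3 to compound 4 (beyond the scatter), because the earlier step of a number 0.41 log units higher from compound 1 to compound 2 (beyond the scatter) was modest and beyond the scatter. Compound 4 is thus expected to give 6.05 in this assay, estimated between 5.75 and 6.4.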

Compound 4, partition coefficient: 6.02
The estimate for compound 4 lay 0.03 log units above the measured number; the range from low to high includes it.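

In this assay methyl in place of hydrogen gives a number 0.41 log units higher from compound 3 to compound 4 (beyond the scatter) and on the other core the same kind of change gives a number 0.41 log units higher from compound 1 to compound 2 (beyond the scatter) so in these two pairs the step carries over from one core to the other at the same printed size. This rests on two pairs only, with the methyl on different carbons: a saturated chain carbon bound to two saturated chain carbons in the new pair, and a saturated chain carbon bound to an oxygen next to a carbonyl group and a saturated chain carbon in the earlier pair. Nothing at hand explains the size of either step.

On these data alone, whether a longer chain, an amine or a carboxylic acid at these places would give a comparable step stays open. So does whether the methyl step holds on any further core.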